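Swapping the pyridine substituent on the amide carbonyl

The source may hold more compounds than are shown below. What is called first, only, known or untested is meant among the compounds shown, and "the series" means these compounds.

Of the compounds shown here, two have been measured in a functional assay on the whole organism (blood) with Rattus norvegicus as the target, with stated times of 24 h and 1 h, at a dose of 5 mg/kg by the intraperitoneal route; on this read-out lower numbers stand for a weaker effect and higher numbers for a stronger effect at the one dose given. Compound 1 `O=C(NC[C@@H]1C[C@@H]2C=C[C@@H]1C2)NS(=O)(=O)N1CCC(CCNC(=O)C(F)(F)F)CC1` gives 22%, and compound 2 `Cc1cccc(C(=O)NCCC2CCN(S(=O)(=O)NC(=O)NC[C@@H]3C[C@@H]4C=C[C@@H]3C4)CC2)n1` gives 20%. Going by the values given here, the one step between them, a number 2 percentage points lower from compound 1 to compound 2 (within the scatter), exchanged trifluoromethyl for 6-methylpyridin-2-yl on a carbonyl carbon, so compound 2 stands within the scatter of compound 1 and neither can be called the stronger of the two. Compound 3 `O=C(NC[C@@H]1C[C@@H]2C=C[C@@H]1C2)NS(=O)(=O)N1CCC(CCNC(=O)c2cc(Cl)ccn2)CC1` has not yet been measured. The change is 4-chloropyridin-2-yl in place of 6-methylpyridin-2-yl on a carbonyl carbon. Among the compounds with values here, no measured step exchanges one pyridinyl group for another at this position; the only step at this carbonyl carbon, from compound 1 to compound 2, stayed within the scatter. Compound 3 is therefore expected to show a step of a number 1 percentage points higher from compound 2 to compound 3 (within the scatter) in this assay, with no clear direction. Compound 3 is estimated at 21%, expected to lie between 8% and 36%.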

Compound 3, a percentage reported as activity, at one dose (the size of the read-out at that dose, not a potency): 32%
Compound 3: the middle estimate sits 11 percentage points below what was measured; measured number inside the range.
By their numbers in this assay, from the lowest: compounds 2, 1 and 3 (each within the scatter of the next, the first and the last beyond it).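

Going by these compounds alone, the group on this carbonyl carbon can move the read-out in this assay: replacing 6-methylpyridin-2-yl with 4-chloropyridin-2-yl, another six-membered aromatic ring with 1 hetero atom, gives a number 12 percentage points higher from compound 2 to compound 3 (beyond the scatter), the first step beyond the scatter. Against trifluoromethyl, the same 4-chloropyridin-2-yl group gives a number 10 percentage points higher from compound 1 to compound 3 (within the scatter), so only the exchange between the two pyridinyl groups clearly separates two compounds. Nothing available here explains the difference.

The two pyridinyl groups differ both in which substituent they carry, methyl or chlorine, and in where it sits, so the compounds shown cannot assign the step to either feature. Testing 6-chloropyridin-2-yl or 4-methylpyridin-2-yl on the same carbonyl carbon would pull these two changes apart.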